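Swapping Hydroxy for Bromo in a Cytotoxicity Series

This account rests on a few compounds, and the source may have more. Where it says the series, first, only, none or still open, it means among the compounds named here.

Compound 1, `O=C(/C=C\c1ccc(O)cc1)N1N=C(c2ccncc2)OC1c1c[nH]c2ccccc12`, was tested in an ADME assay on HeLa cells (Homo sapiens) for cytotoxicity, read by MTT assay, with a stated time of 72 h; a higher number here means a weaker inhibitor of growth, a lower number a stronger inhibitor of growth. In this assay compound 1 gives > 30 ug/mL, which is a limit of the assay rather than a number. Compound 2, `O=C(/C=C\c1cccc([N+](=O)[O-])c1)N1N=C(c2ccncc2)OC1c1c[nH]c2ccccc12`, gives > 30 ug/mL in this assay, again a limit. Compound 3, `O=C(/C=C/c1c(Cl)cccc1Cl)N1N=C(c2ccncc2)OC1c1c[nH]c2ccccc12`, gives > 30 ug/mL, also a limit. Among the compounds with values here, because of the limit of > 30 ug/mL in this assay, at which 3 of the 3 values shown sit, no measured step can be sized: the step that the two limits leave unreadable from compound 1 to compound 2, the step that the two limits leave unreadable from compound 1 to compound 3 and the step that the two limits leave unreadable from compound 2 to compound 3 all stay unreadable. What they do show is that three different substituents on the aryl arm of the shared core left growth inhibition at the limit.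

Compound 4, `O=C(/C=C\c1ccc(Br)cc1)N1N=C(c2ccncc2)OC1c1c[nH]c2ccccc12`, differs from compound 1 in one place: bromo in place of hydroxy on an aromatic carbon. The three measured steps bear on this change only in that sense, since none of them could be read. For compound 4 the step that the limit leaves unreadable from compound 1 to compound 4 is therefore expected to stay within the scatter. Compound 4 is estimated at 45 ug/mL, with a range from 20 ug/mL to 120 ug/mL, and is expected to be reported most likely as a limit once more.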

Compound 4, concentration for 50% growth inhibition: > 30 ug/mL
Compound 4: only a limit was reported; the forecaster's own chance of this, stated with the estimate: 85%; the middle value does not contradict the limit.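

In this assay compound 4 gives > 30 ug/mL and this is again a limit of the assay, not a number. Within the data shown here, no new step from compound 1, compound 2 or compound 3 to compound 4 can be read, because all four compounds sit at that limit: (the limit of > 30 ug/mL in this assay, at which 4 of the 4 values shown sit). The compounds shown leave open how strongly any of them inhibits growth, and whether any change on the aryl arm of the shared core alters it.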